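The source may hold more compounds than are shown below. What is called first, only, known or untested is meant among the compounds shown, and "the series" means these compounds.

Measured so far:
compound 1 `CCc1cccc2c(=O)c(-c3nn[nH]n3)c[nH]c12` — > 25 mg/kg
compound 2 `Cc1cccc2cc(C(=O)O)cnc12` — > 25 mg/kg

Compound 1 `CCc1cccc2c(=O)c(-c3nn[nH]n3)c[nH]c12` was tested in a functional assay on the whole organism (strain Sprague-Dawley) for inhibition, with Rattus norvegicus as the target; on this read-out lower numbers stand for an effect already at smaller amounts and higher numbers for an effect only at larger amounts of compound. In this assay compound 1 gives > 25 mg/kg, which is a limit of the assay and not a number. Compound 2 `Cc1cccc2cc(C(=O)O)cnc12` was tested in the same assay. In this assay compound 2 gives > 25 mg/kg, again a limit and not a number. Both values shown therefore sit at the same boundary: the limit of > 25 mg/kg in this assay, at which 2 of the 2 values shown sit. Compound 1 stands nowhere in particular on a scale of numbers; all that is known is that it did not show an effect up to that limit.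

Compound 3 `COc1cccc2c(=O)c(-c3nn[nH]n3)c[nH]c12` has not yet been measured in this assay. It differs from compound 1 in one place: methoxy in place of ethyl on an aromatic carbon. Within the data shown here, no step between two measured compounds exists in this set, so there is nothing measured to say how large a change this kind of exchange brings. With compound 1 sitting at the limit, the step from compound 1 to compound 3 is expected to be small, with no clear direction beyond the scatter, as a step that the limit leaves unreadable from compound 1 to compound 3 expresses. For compound 3 the expected value in this assay is 30 mg/kg, within a range from 12 mg/kg to 80 mg/kg, and it is quite likely that the assay again reports only a limit.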

Compound 3, minimum effective dose: 0.312 mg/kg
Compound 3: the middle estimate sits 96-fold (1.98 log units) above what was measured; the measured number lies below the stated range.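

Among these compounds, the exchange of ethyl for methoxy on this aromatic carbon of the shared core brings an at least 80-fold lower number from compound 1 to compound 3 (1.90 log units; beyond the scatter) in this assay, so the position is not indifferent to what sits on it, something the earlier compounds, with no number among them, could not show. As far as these compounds go, compound 1 gives > 25 mg/kg, which is a limit and not a number, so the true size of the step remains open on one side. The two groups hold the same count of 2 heavy atoms and differ in a carbon against an oxygen and in the 1 hydrogen-bond acceptor that methoxy carries, and compound 3 is the only compound shown to leave the boundary: the limit of > 25 mg/kg in this assay, at which 2 of the 3 values shown sit.

From the compounds shown here alone, a single exchange cannot tell which feature of methoxy goes with the step, and whether a hydroxyl, an amine or a longer chain such as ethoxy on this carbon would keep the low number remains open. Compound 2 differs from compound 1 in more than one place, so it offers no comparison on this question.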